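The source may report more compounds than this note shows. Statements on the series, on what has been measured and on what is new or still open speak of the compounds shown alone.

Working notes on the butanedioxy-linked ketone acids.

Compound 2 `Cc1cc(OCCCCOc2ccc(C(=O)CC3CCCC3)c(O)c2C)ccc1C(=O)O` is the reference point. In an ADME assay on a cell-free system (plasma, Rattus norvegicus) for metabolic stability, read by LC-MS, with a stated time of 60 min, tested at 100 uM (on this read-out lower numbers stand for a less stable compound and higher numbers for a more stable compound), compound 2 gives 114%, the top number among the three measured. Compound 1 `Cc1c(OCCCCOc2cccc(C(=O)O)c2)ccc(C(=O)CC(C)C)c1C` gives 106% in this assay, which lies within the scatter of compound 2. Compound 3 `Cc1cc(OCCCCOc2ccc(C(=O)CC(C)C)c(O)c2C)ccc1C(=O)O` gives 101% in this assay; the step of a number 13 percentage points lower from compound 2 to compound 3 (beyond the scatter) is the only one measured, and it concerns the group on the saturated chain carbon bound to the carbonyl carbon, not the aryl acid end.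

Compound 4 `Cc1c(OCCCCOc2cccc(C(=O)O)c2)ccc(C(=O)CC2CCCC2)c1O` keeps the cyclopentyl of compound 2 and changes the aryl acid end: 3-carboxyphenyl in place of 4-carboxy-3-methylphenyl on an oxygen on a saturated carbon. Among the compounds with values here, no measured step isolates this change. Compound 1 and compound 3 carry the two aryl acid ends in question but also differ elsewhere. In this assay compound 1 gives 106%. In this assay compound 3 gives 101%. These two values show only that both ends sit in the same region in this assay. Nothing measured points to a step beyond the scatter, so the expected step from compound 2 to compound 4 in this assay is a number 6 percentage points lower from compound 2 to compound 4 (within the scatter), within the scatter.

Compound 4 is therefore expected to give about 108% in this assay, with a range of 94% to 122%.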

Compound 4, percent of the compound remaining: 99%
For compound 4 the middle estimate is 9 percentage points above the measured one; the range from low to high includes it.
By their numbers in this assay, from the lowest: compounds 4, 3, 1 and 2 (each within the scatter of the next, the first and the last beyond it).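

Within the data shown here, the change to 3-carboxyphenyl in place of 4-carboxy-3-methylphenyl on an oxygen on a saturated carbon gives a number 15 percentage points lower from compound 2 to compound 4 (beyond the scatter) in this assay, and this is the only step measured at the aryl acid end. Among these compounds, until now the only measured step was at the other end of the molecule, on the saturated chain carbon bound to the carbonyl carbon, where isopropyl in place of cyclopentyl gives a number 13 percentage points lower from compound 2 to compound 3 (beyond the scatter) in the same assay, so starting from compound 2, a change at either end lowers the number beyond the scatter. Nothing at hand bears on why the aryl acid change has this effect.

The change removes a methyl and alters where the carboxy group sits in a single step, and the compounds shown do not separate these two contributions, nor do they show whether the step holds with isopropyl in place of cyclopentyl. Also open, on these data alone, is how this read-out responds at the same place when a tetrazole stands in place of the carboxylic acid, or when a longer chain replaces the butanedioxy link.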